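The compounds below may be only part of what the source reports. "The series", "measured", "known", "first", "only" and "open" are said of these compounds alone.

Of the compounds shown here, three built on one shared core have been tested in an ADME assay on NIH3T3 cells (Mus musculus) for cytotoxicity, read by XTT assay, with a stated time of 24 h; a lower number here means a stronger inhibitor, a higher number a weaker inhibitor. Compound 1 `Fc1ccc(C2CC(c3ccc(Cl)s3)=NN2c2nc(-c3ccccc3)cs2)cc1` gives > 500 ug/mL, which is a limit of the assay rather than a number. Compound 2 `Fc1ccc(C2CC(c3ccc(Cl)s3)=NN2c2nc(-c3ccc(Br)cc3)cs2)cc1` gives > 500 ug/mL, again a limit and not a measured value. Compound 3 `Cc1ccc(C2=NN(c3nc(-c4ccc(Cl)cc4)cs3)C(c3ccc(F)cc3)C2)s1` gives > 500 ug/mL, likewise a limit. Because (the limit of > 500 ug/mL in this assay, at which 3 of the 3 values shown sit), none of the three has shown an effect on these cells within the tested range. Within the data shown here, the only step between two measured compounds that differ in a single place, a step that the two limits leave unreadable from compound 1 to compound 2, brings bromo in place of hydrogen on an aromatic carbon, and since both of its ends are limits its size cannot be read.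

Compound 4 `Cc1ccc(-c2csc(N3N=C(c4ccc(C)s4)CC3c3ccc(F)cc3)n2)cc1` has not yet been measured in this assay. It differs from compound 3 by methyl in place of chloro on an aromatic carbon. Among the measured compounds shown here, no measured step bears on an exchange of methyl for chloro, and the one step that exists gives no size at all, so the expectation for compound 4 can rest only on where compound 3 stands. The step from compound 3 to compound 4 is therefore expected to be a step that the limit leaves unreadable from compound 3 to compound 4, nothing beyond the usual scatter. Compound 4 is estimated at 600 ug/mL, with a range from 300 ug/mL to 1500 ug/mL, and most probably the assay will again report only a limit.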

Compound 4, half-maximal inhibitory concentration: > 500 ug/mL
Compound 4: only a limit was reported; the forecaster's own chance of this, stated with the estimate: 85%; the middle value does not contradict the limit.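

No step can be read between compound 3 and compound 4, so the exchange of chloro for methyl has no measurable size, because both ends are limits and not numbers: the limit of > 500 ug/mL in this assay, at which 4 of the 4 values shown sit.

The compounds shown leave open at what concentration, if any, this series affects the cells in this assay, and how any change on the shared core would shift that value.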